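Cyclopentylamino to (4-fluorophenyl)amino: tolerated concentration

This account rests on a few compounds, and the source may have more. Where it says the series, first, only, none or still open, it means among the compounds named here.

Measured compounds:
compound 1 `Cc1ccn2c(Nc3ccccn3)c(-c3ccccn3)nc2c1`: > 50000 nM, a limit of the assay
compound 2 `COc1ccc(-c2nc3ccccn3c2NC2CCCC2)nc1`: 19300 nM

In an ADME assay on THP-1 cells (Homo sapiens) for cytotoxicity (a higher number here means that more compound is tolerated, a lower number that less compound is tolerated), compound 2 gives 19300 nM, the only number shown in this series. The value of compound 1 is a limit of the assay, not a number: the limit of > 50000 nM in this assay, at which 1 of the 2 values shown sits.

Compound 3 `COc1ccc(-c2nc3ccccn3c2Nc2ccc(F)cc2)nc1` differs from compound 2 in one place: 4-fluorophenyl in place of cyclopentyl on a nitrogen on an aromatic ring. Among the compounds with values here, no measured step of this kind exists, so the size of the step rests on expectation alone. The step of a 1.0-fold lower number from compound 2 to compound 3 (0.01 log units; within the scatter) is expected to stay within the usual scatter. Compound 3 is estimated at 19000 nM, between 7000 nM and 50000 nM.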

Compound 3, half-maximal cytotoxic concentration: 15400 nM
Compound 3: middle estimate off by 1.2-fold (0.09 log units), on the high side; measured number inside the range.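

Within the data shown here, at this nitrogen on an aromatic ring, the first measured step in this assay is a 1.3-fold lower number from compound 2 to compound 3 (0.10 log units; within the scatter), so a five-membered non-aromatic ring of carbon and a six-membered aromatic ring of carbon read alike in this pair. Compound 1 differs from both in more than one place and gives a limit of the assay, not a number: the limit of > 50000 nM in this assay, at which 1 of the 3 values shown sits.

Still open, going by these compounds, is whether plain phenyl would read the same as 4-fluorophenyl. Also open, on these data alone, is whether a carboxylic acid or a morpholine ring carried on this nitrogen would produce a step beyond the scatter.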